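Adding an Ester Chain to the Urea of Compound 3

The source may report more compounds than this note shows. Statements on the series, on what has been measured and on what is new or still open speak of the compounds shown alone.

Compound 3 `Cc1cn([C@@H]2O[C@H](CO[Si](C)(C)C(C)(C)C)[C@@]3(OS(=O)(=O)C=C3NC(N)=O)[C@H]2O[Si](C)(C)C(C)(C)C)c(=O)n(C)c1=O` gives 3700 nM in a functional assay on MT4 cells (Homo sapiens) (on this read-out higher numbers stand for lower toxicity in this test and lower numbers for higher toxicity in this test), the lowest of the two numbers shown, and compound 2 `Cc1cn([C@@H]2O[C@H](CO[Si](C)(C)C(C)(C)C)[C@@]3(OS(=O)(=O)C=C3NC(=O)c3ccccc3)[C@H]2O[Si](C)(C)C(C)(C)C)c(=O)n(C)c1=O` at 4900 nM lies within the scatter of it. Compound 1 `Cc1cn([C@@H]2O[C@H](CO[Si](C)(C)C(C)(C)C)[C@@]3(OS(=O)(=O)C=C3NCCC(=O)OCc3ccccc3)[C@H]2O[Si](C)(C)C(C)(C)C)c(=O)n(C)c1=O` reaches only the limit > 250000 nM in this assay. Compound 4 `CCOC(=O)CNC(=O)NC1=CS(=O)(=O)O[C@@]12[C@@H](CO[Si](C)(C)C(C)(C)C)O[C@@H](n1cc(C)c(=O)n(C)c1=O)[C@@H]2O[Si](C)(C)C(C)(C)C` differs from compound 3 by (ethoxycarbonyl)methyl in place of hydrogen on an amide-type nitrogen. Among the compounds with values here, no measured step makes this exact change. The step of a 1.3-fold lower number from compound 2 to compound 3 (0.12 log units; within the scatter) shows that swapping the group on the carbonyl carbon alters little. Compound 1, which carries an ester chain, sits at the limit (the limit of > 250000 nM in this assay, at which 1 of the 3 values shown sits), and the step of an at least 67-fold lower number from compound 1 to compound 3 (1.82 log units; beyond the scatter) is large. Since compound 4 also carries an ester chain, a rise is expected, a 5.4-fold higher number from compound 3 to compound 4 (0.73 log units; beyond the scatter), though its size is uncertain. Compound 4 is therefore estimated at 20000 nM, between 4000 nM and 200000 nM.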

Compound 4, half-maximal cytotoxic concentration: 3780 nM
Compound 4: the middle estimate sits 5.3-fold (0.72 log units) above what was measured, outside the stated range (below it).
By their numbers in this assay, from the lowest: compounds 3, 4 and 2 (each within the scatter of the next). At a limit, above all of these: compound 1.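

An ester chain on this amide-type nitrogen does not by itself shift the number in this assay: the result is a 1.0-fold higher number from compound 3 to compound 4 (0.01 log units; within the scatter), and likewise a 1.3-fold lower number from compound 2 to compound 4 (0.11 log units; within the scatter). Compound 1 remains alone at a limit, which is not a true number: the limit of > 250000 nM in this assay, at which 1 of the 4 values shown sits. Even with an ester chain on both sides, the gap stays large, with an at least 66-fold lower number from compound 1 to compound 4 (1.82 log units; beyond the scatter).

From the compounds shown here alone, it remains open whether a carboxylic acid or an amine in place of the ester would leave the number unchanged. Going by these compounds, a longer chain on this nitrogen is equally open.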